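From hydroxybenzyl to pyridylmethyl ether: an untested step

The source may report more compounds than this note shows. Statements on the series, on what has been measured and on what is new or still open speak of the compounds shown alone.

The measured compounds and their values in an assay (strain Wistar) for inhibition of Amine oxidase [flavin-containing] A (Rattus norvegicus) (a lower number here means a stronger inhibitor, a higher number a weaker inhibitor), are:
compound 1 `NC(=O)Cc1cc(=O)oc2cc(OCc3cccc(Cl)c3)ccc12` with 26000 nM;
compound 2 `NC(=O)Cc1cc(=O)oc2cc(OCc3cccc(F)c3)ccc12` with 70000 nM;
compound 3 `NC(=O)Cc1cc(=O)oc2cc(OCc3cccc(O)c3)ccc12` with 4270 nM.

Compound 3 gives the lowest of the three numbers in this assay. Its nearest neighbour is compound 1, separated by a 6.1-fold lower number from compound 1 to compound 3 (0.78 log units; beyond the scatter); compound 2 is further away, with a 16-fold lower number from compound 2 to compound 3 (1.21 log units; beyond the scatter). The two halogen analogues are themselves apart by a 2.7-fold higher number from compound 1 to compound 2 (0.43 log units; beyond the scatter).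

Compound 4 `NC(=O)Cc1cc(=O)oc2cc(OCc3ccncc3)ccc12` differs from compound 3 in one place: pyridin-4-yl in place of 3-hydroxyphenyl on a saturated chain carbon bound to an oxygen on an aromatic ring. Cut one bond further out, the change reads 3-hydroxybenzyl to (pyridin-4-yl)methyl; the ring that leaves carries one hydrogen-bond donor and one acceptor, the ring that enters carries no donor and one acceptor.

Among the measured compounds shown here, none of the measured steps exchanges the ring itself or removes the donor, so they bear on this change only loosely. What they show is that the hydroxy-bearing ring of compound 3 gives a clearly lower number than either halogen-bearing ring, and that the three variants span a wide range. With the donor gone in compound 4, the expected step in this assay is toward a higher number, of moderate size, a 3.5-fold higher number from compound 3 to compound 4 (0.55 log units; beyond the scatter). The estimate for compound 4 is therefore 15000 nM, within a range from 3000 nM to 80000 nM.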

Compound 4, half-maximal inhibitory concentration: 26500 nM
Beside the measured number, compound 4's estimate is 1.8-fold (0.25 log units) below it, and the stated range covers the measured number.
By their numbers in this assay, from the lowest: compound 3; then compounds 1 and 4 (each within the scatter of the next); then compound 2.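

In this assay, exchanging the whole ring on a saturated chain carbon bound to an oxygen on an aromatic ring gives a 6.2-fold higher number from compound 3 to compound 4 (0.79 log units; beyond the scatter) and so costs compound 3 its lead, which the halogen swaps alone could not show. The pyridin-4-yl ring cannot be told apart from the 3-chlorophenyl ring, with a 1.0-fold higher number from compound 1 to compound 4 (0.01 log units; within the scatter) within the scatter, and it still improves on the 3-fluorophenyl ring, with a 2.6-fold lower number from compound 2 to compound 4 (0.42 log units; beyond the scatter) as the listed step. Among these four compounds, then, the one ring with a hydrogen-bond donor, in compound 3, gives the lowest number, and a ring nitrogen in compound 4 does not recover that position, though four compounds can only show this as a coincidence of features.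

The compounds shown leave open whether the step follows the loss of the hydroxy group or the entry of the ring nitrogen, a question that a plain phenyl, a pyridin-3-yl or a 3-aminophenyl ring at this place would help to separate. Nothing given here accounts for the size or direction of the step.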